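A few compounds are considered here, and "the series" means these few. Any claim that something is new, unique, unknown or untested is made for them only; others in the source may bear on it.

Working notes on the series. Compound 1 `COc1ccccc1/C=C1/C(=O)N(c2ccc(Cl)cc2)N=C1C` is measured in an assay for inhibition of Alpha amylase (Homo sapiens), with a stated time of 10 min (a higher number here means a weaker inhibitor, a lower number a stronger inhibitor), where compound 1 gives 2020 nM. Compound 2 `COc1ccc(OC)c(/C=C2/C(=O)N(c3ccc(Cl)cc3)N=C2C)c1` carries methoxy in place of hydrogen on an aromatic carbon and in this assay compound 2 gives 2130 nM; the step is a 1.1-fold higher number from compound 1 to compound 2 (0.02 log units; within the scatter). Compound 3 `COc1cc(/C=C2/C(=O)N(c3ccc(Cl)cc3)N=C2C)cc(OC)c1` gives 2210 nM in this assay; its values and those of compound 1 and compound 2 sit within the scatter of one another, and the difference between the cores of compound 1 and compound 3 is not broken down here. Compound 4 `COc1cc(/C=C2/C(=O)N(c3ccc(Cl)cc3)N=C2C)cc(OC)c1OC`, not yet measured, differs from compound 3 by methoxy in place of hydrogen on an aromatic carbon, the same kind of change as that from compound 1 to compound 2, though the surroundings differ: there the methoxy sat meta to a large group and para to a methoxy group, here ortho to two methoxy groups and para to a large group. The step is expected to be a 1.0-fold higher number from compound 3 to compound 4 (0.02 log units; within the scatter), flat like a 1.1-fold higher number from compound 1 to compound 2 (0.02 log units; within the scatter), because a 1.1-fold higher number from compound 1 to compound 2 (0.02 log units; within the scatter) lay within the scatter. Compound 4 is estimated at 2300 nM, between 1200 nM and 4500 nM.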

Compound 4, half-maximal inhibitory concentration: 2190 nM
Compound 4: the middle estimate sits 1.1-fold (0.02 log units) above what was measured; low and high end bracket the measured number.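

In this assay the added methoxy gives a 1.0-fold lower number from compound 3 to compound 4 (0.00 log units; within the scatter). Set beside the earlier step, the same change shows no detectable difference between the two cores: the same change on two cores in this assay, a 1.1-fold higher number (0.02 log units; within the scatter) from compound 1 to compound 2 and a 1.0-fold lower number (0.00 log units; within the scatter) from compound 3 to compound 4, 1.1-fold (0.03 log units) apart, within the scatter of two such steps. This shows that the change stays flat in the two surroundings compared, but two flat steps do not show that it would stay flat on other cores or in other places, and they give no cause for the flatness.

The compounds shown leave open whether an amine or a carboxylic acid in place of a methoxy, or a longer chain such as butoxy, would give a step beyond the scatter.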